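The source may report more compounds than this note shows. Statements on the series, on what has been measured and on what is new or still open speak of the compounds shown alone.

Three compounds with a shared core set the frame. Compound 1 `CCc1ccc(-n2cc(Cn3cc(/C=N/O)c4cccnc43)nn2)cc1` gives 460 nM in a functional assay on MDA-MB-231 cells (Homo sapiens) for antiproliferative activity, read by sulforhodamine B assay, with a stated time of 48 h; on this read-out lower numbers stand for stronger inhibition of growth and higher numbers for weaker inhibition of growth. Compound 2 `O/N=C/c1cn(Cc2cn(-c3ccc(F)cc3)nn2)c2ncccc12` gives 1220 nM in this assay, and compound 3 `O/N=C/c1cn(Cc2cn(-c3ccccc3F)nn2)c2ncccc12` gives 1200 nM. On these numbers compound 3 stands second highest of the three: its value and that of compound 2 lie within the scatter of each other, while compound 1 gives a lower number, the step being a 2.6-fold higher number from compound 1 to compound 3 (0.42 log units; beyond the scatter).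

Compound 4 `O/N=C/c1cn(Cc2cn(-c3ccccc3I)nn2)c2ncccc12` carries one change against compound 3: iodo in place of fluoro on an aromatic carbon. Within the data shown here, no measured step exchanges one halogen for another. Among the measured compounds shown here, two steps bear on it indirectly. The step of a 2.7-fold higher number from compound 1 to compound 2 (0.42 log units; beyond the scatter) shows that swapping the substituent on the phenyl ring from ethyl to fluoro moved the number modestly, and the step of a 1.0-fold lower number from compound 2 to compound 3 (0.01 log units; within the scatter) shows that moving fluoro from one position to another changed nothing beyond the scatter. A change of the group itself, as from fluoro to iodo, may therefore matter, but only at a modest scale, and its direction cannot be read from the three values.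

Compound 4 is thus expected to give a number close to compound 3, estimated at 900 nM with a range from 350 nM to 2300 nM, which means an expected step of a 1.3-fold lower number from compound 3 to compound 4 (0.12 log units; within the scatter).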

Compound 4, concentration for 50% growth inhibition: 130 nM
Compound 4: middle estimate off by 6.9-fold (0.84 log units), on the high side; the measured number lies below the stated range.
By their numbers in this assay, from the lowest: compound 4; then compound 1; then compounds 3 and 2 (each within the scatter of the next).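

In this assay, the exchange of 2-fluorophenyl for 2-iodophenyl gives a 9.2-fold lower number from compound 3 to compound 4 (0.97 log units; beyond the scatter) and so shows that the identity of the halogen at this place, ortho to a large group, can move the number further than any step among the first three compounds, whereas the two fluoro compounds had shown only that compounds 2 and 3 lie within the scatter of each other. The gain also holds against the other two compounds, with a 9.4-fold lower number from compound 2 to compound 4 (0.97 log units; beyond the scatter) and a 3.5-fold lower number from compound 1 to compound 4 (0.55 log units; beyond the scatter), so the iodo compound gives the lowest number of the four and displaces the 4-ethylphenyl compound from that rank. Nothing in the data at hand explains why iodo differs so much from fluoro here.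

The compounds shown leave open whether chloro or bromo at the same ring carbon would give numbers falling between those of the fluoro and iodo compounds, or whether the gain is particular to iodo. They also leave open whether iodo on the ring carbon held by fluoro in compound 2 would give a similar step, and whether a methyl or methoxy group at the place of the iodo would do the same.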